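Cytotoxicity notes: diethylamino to piperidinyl amide change

The source may hold more compounds than are shown below. What is called first, only, known or untested is meant among the compounds shown, and "the series" means these compounds.

Measured so far:
compound 1 `COc1ccc(-c2nc3cc(Cl)c(Cl)cc3[nH]2)c(N)c1`: in an ADME assay on BHK cells (Mesocricetus auratus) for cytotoxicity, read by MTT assay, with a stated time of 96 h (on this read-out higher numbers stand for lower toxicity in this test and lower numbers for higher toxicity in this test), compound 1 gives > 100000 nM, a limit of the assay, not a number.
compound 2 `CCN(CC)CC(=O)Nc1ccc(-c2nc3cc(C(F)(F)F)ccc3n2C)cc1`: in this assay compound 2 gives 16000 nM.

Compound 2 thus holds the only number shown; the other value is a limit, (the limit of > 100000 nM in this assay, at which 1 of the 2 values shown sits). Compound 3 `Cn1c(-c2ccc(NC(=O)CN3CCCCC3)cc2)nc2cc(C(F)(F)F)ccc21` differs from compound 2 by piperidin-1-yl in place of diethylamino on a saturated chain carbon bound to a carbonyl carbon. For the measured compounds named here, no step between measured compounds is available to guide this change. The expected step of no change at the digits printed from compound 2 to compound 3 (within the scatter) is none beyond the usual scatter of this assay, the amide being kept and one amine exchanged for another. Compound 3 in this assay is estimated at 16000 nM, within 6000 nM to 45000 nM.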

Compound 3, half-maximal cytotoxic concentration: > 100000 nM
Compound 3 gave a limit, no number; the forecaster's own chance of this, stated with the estimate: 10%; middle value at least 6.2-fold (0.79 log units) away from the limit.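

Piperidin-1-yl in place of diethylamino on a saturated chain carbon bound to a carbonyl carbon gives an at least 6.2-fold higher number from compound 2 to compound 3 (0.79 log units; beyond the scatter), so the amine at this place is not indifferent in this assay. Compound 3 gives > 100000 nM, a limit of the assay and not a number. The step therefore has a lower bound only, and its full size cannot be read: the limit of > 100000 nM in this assay, at which 2 of the 3 values shown sit.

As far as these compounds go, whether the ring closure or the added carbon carries the step stays open. From the compounds shown here alone, how pyrrolidin-1-yl, morpholin-4-yl or a longer chain to the amine would read at this place also stays open.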